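The source may report more compounds than this note shows. Statements on the series, on what has been measured and on what is new or still open speak of the compounds shown alone.

Compound 1 `Nc1nc2c(ncn2/C=C2/CC2(CO)CO)c(=O)[nH]1` and compound 3 `CCCCOc1nc(N)nc2c1ncn2/C=C1/CC1(CO)CO` share their core with compound 2 `Nc1nc(N2CCCC2)c2ncn(/C=C3/CC3(CO)CO)c2n1`. In an ADME assay on HFF cells (Homo sapiens) for cytotoxicity, with a stated time of 8 days (on this read-out higher numbers stand for lower toxicity in this test and lower numbers for higher toxicity in this test), compound 2 gives only a limit, > 300000 nM. Compound 1 likewise reaches only a limit, > 300000 nM. Compound 3 also yields only a limit, > 300000 nM. The step that the two limits leave unreadable from compound 2 to compound 3 therefore cannot be read in size. Compound 4 `CCCCSc1nc(N)nc2c1ncn2/C=C1/CC1(CO)CO` differs from compound 2 by butylsulfanyl in place of pyrrolidin-1-yl on an aromatic carbon. Within the data shown here, no measured step speaks readably to this exchange of pyrrolidin-1-yl for butylsulfanyl; the only evidence is the limit of > 300000 nM in this assay, at which 3 of the 3 values shown sit. In this assay no step beyond the scatter is expected, and compound 4 is expected to sit at the same limit, with an expected step of a number no higher from compound 2 to compound 4 (the limit leaves the size open). Compound 4 is estimated at 300000 nM, between 100000 nM and 1000000 nM.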

Compound 4, half-maximal cytotoxic concentration: > 300000 nM
Compound 4 was reported as a limit (the forecaster's own chance of this, stated with the estimate: 85%); the middle value sits exactly at the limit.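

In this assay compound 4 gives only a limit, > 300000 nM. Among these compounds, no step from compound 2 or compound 3 to compound 4 can be read. The compounds shown leave open whether exchanging the group on that aromatic carbon changes this read-out at all.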